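Shortening the Side Chain on a Shared Diaryl Core

The source may report more compounds than this note shows. Statements on the series, on what has been measured and on what is new or still open speak of the compounds shown alone.

Among the measured compounds shown here, compound 1 `CCCCC[C@H](C(C)C)C(c1ccc(O)c(OC)c1)c1ccc(O)c(OC)c1` is the only compound here with a measured number: in a functional assay on HeLa cells (Homo sapiens) for cytotoxicity, read by WST assay, with a stated time of 48 h (a lower number here means a stronger inhibitor, a higher number a weaker inhibitor), compound 1 gives 9200 nM. Compound 2 `COc1cc(C(c2ccc(O)c(OC)c2)[C@H](C)[C@H](C)CO)ccc1O` has no number in this assay; for compound 2 the result is a limit of the assay, > 100000 nM. The step of an at least 10-fold higher number from compound 1 to compound 2 (1.03 log units; beyond the scatter) is large, and the result for compound 2 sits at the limit of > 100000 nM in this assay, at which 1 of the 2 values shown sits. Compound 3 `COC[C@@H](C)[C@@H](C)C(c1ccc(O)c(OC)c1)c1ccc(O)c(OC)c1` makes a related change: 2-(methoxymethyl)-1-methylpropyl in place of 1-isopropylhexyl on a saturated chain carbon bound to two aromatic carbons. For the measured compounds named here, the entering group differs from the one in compound 2 only in carrying methoxymethyl where that group carries hydroxymethyl. Going by the values given here, with the step from compound 1 to compound 2 as the sole guide, a large rise in this assay is expected for compound 3, a 6.5-fold higher number from compound 1 to compound 3 (0.81 log units; beyond the scatter). Compound 3 is therefore estimated at 60000 nM, within 20000 nM to 200000 nM, with a fair chance that only a limit is reported.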

Compound 3, half-maximal inhibitory concentration: > 100000 nM
Compound 3: a limit, no number; the forecaster's own chance of this, stated with the estimate: 50%; at least 1.6-fold (0.22 log units) between middle value and limit.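

Compound 3 gives a limit in this assay, > 100000 nM. With methoxymethyl in the entering group instead of hydroxymethyl, replacing 1-isopropylhexyl still gives an at least 10-fold higher number from compound 1 to compound 3 (1.03 log units; beyond the scatter), so a free hydroxyl in the entering group is not required for this large rise. The step from compound 2 to compound 3, methyl in place of hydrogen on an oxygen, cannot be read, and this part of the comparison rests on two limits: the limit of > 100000 nM in this assay, at which 2 of the 3 values shown sit.

Compound 1 remains the only compound with a measured number, and the compounds shown do not separate the effect of the oxygen in the entering groups from that of the change in the chain. Going by these compounds, whether an all-carbon chain of another length or an amine in this place would keep a measurable number remains open.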